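Bromo for difluoromethyl on a shared oxime core

A few compounds are considered here, and "the series" means these few. Any claim that something is new, unique, unknown or untested is made for them only; others in the source may bear on it.

Compound 1 `NS(=O)(=O)CC(=O)NCCSc1nonc1/C(=N/O)Nc1cccc(C(F)F)c1` was examined in an ADME assay on isolated protein for pharmacokinetics, with UDP-glucuronosyltransferase 1A9 (Homo sapiens) as the target, read by LC-MS, with a stated time of 60 min, at 37 degrees C, tested at 1 uM, in the presence of a further agent that is not named here; a lower number here means that the compound disappears faster, a higher number that the compound lasts longer. In this assay compound 1 gives > 3 h, which is a limit of the assay rather than a number; the record notes (the limit of > 3 h in this assay, at which 1 of the 2 values shown sits), so where compound 1 truly stands is known only as a range. For the measured compounds named here, a second compound on the same core, compound 2 `C[C@H](CSc1nonc1/C(=N/O)Nc1ccc(F)c(Br)c1)NC(=O)CS(N)(=O)=O`, gives 1.33 h in this assay; it carries a different chain and a different aryl ring, and no single step separates it from compound 1.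

Compound 3 `NS(=O)(=O)CC(=O)NCCSc1nonc1/C(=N/O)Nc1cccc(Br)c1` has not yet been measured in this assay. It differs from compound 1 by bromo in place of difluoromethyl on an aromatic carbon, on the aromatic carbon meta to the large group. Going by the values given here, no measured pair covers this exchange, so the size of the step is open. Because compound 1 sits at the limit of > 3 h in this assay, at which 1 of the 2 values shown sits, the step from compound 1 to compound 3 is expected to be modest, an at least 1.2-fold lower number from compound 1 to compound 3 (0.07 log units; that floor lies within the scatter), with a fair chance that compound 3 also returns only a limit. Compound 3 is therefore estimated at 2.5 h, with a range from 1.2 h to 5 h.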

Compound 3, half-life: 0.955 h
Compound 3: the middle estimate sits 2.6-fold (0.42 log units) above what was measured; measured number below the stated range.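

On the aromatic carbon meta to a large group, the exchange of difluoromethyl for bromo now has its first measured pair on the shared core, and in this assay it gives an at least 3.1-fold lower number from compound 1 to compound 3 (0.49 log units; beyond the scatter). The position is therefore not indifferent to what it carries: with the 3-bromophenyl group, compound 3 returns a readable half-life of 0.955 h. The 3-(difluoromethyl)phenyl group leaves compound 1 at a limit of the assay. The step is a floor rather than a full size, because the value of compound 1 is a limit and not a number: the limit of > 3 h in this assay, at which 1 of the 3 values shown sits.

As far as these compounds go, whether a chloro, trifluoromethyl or methoxy group on the same aromatic carbon would behave more like bromo or like difluoromethyl remains open, as does the effect of moving bromo to another carbon of the ring. The compounds shown also do not tell whether the exchange would bring a step of similar size on a different chain, such as the branched chain of compound 2, or why the half-life changes at all.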